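The source may hold more compounds than are shown below. What is called first, only, known or untested is meant among the compounds shown, and "the series" means these compounds.

Measured so far:
compound 1 `O=C(Nc1cccc(C(=O)O/N=C2\CCCc3noc(-c4cccc(F)c4)c32)c1)c1cccc(F)c1`: > 25000 nM (a limit of the assay, not a number)
compound 2 `CC1(C)C/C(=N\OC(=O)c2cccc(NC(=O)c3cccc(F)c3)c2)c2c(-c3ccc(F)cc3)noc2C1`: 5200 nM
compound 3 `CC1(C)C/C(=N\OC(=O)c2cccc(NC(=O)c3cccc(F)c3)c2)c2c(noc2-c2cccc(F)c2)C1`: > 25000 nM (a limit of the assay, not a number)

All three were tested in a functional assay on MCF7 cells (Homo sapiens) for antiproliferative activity, read by MTT assay, with a stated time of 72 h; on this read-out lower numbers stand for stronger inhibition and higher numbers for weaker inhibition. Among the measured compounds shown here, compound 2 is the only compound with a measured number, 5200 nM, while two of the three values sit at the limit of > 25000 nM in this assay, at which 2 of the 3 values shown sit. Compound 4 `COc1ccc(-c2noc3c2/C(=N/OC(=O)c2cccc(NC(=O)c4cccc(F)c4)c2)CC(C)(C)C3)cc1OC` differs from compound 2 by 3,4-dimethoxyphenyl in place of 4-fluorophenyl on an aromatic carbon. For the measured compounds named here, no measured pair shows this change alone, so its effect is unknown; the expected step from compound 2 to compound 4 is a 1.2-fold higher number from compound 2 to compound 4 (0.06 log units; within the scatter), no further than the scatter. Compound 4 is estimated at 6000 nM, between 2000 nM and 25000 nM.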

Compound 4, half-maximal inhibitory concentration: > 25000 nM
Compound 4: only a limit was reported; the forecaster's own chance of this, stated with the estimate: 30%; at least 4.1-fold (0.61 log units) between middle value and limit.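

In this assay, the first step read at this aromatic carbon of the five-membered ring shows that the group there matters: 3,4-dimethoxyphenyl in place of 4-fluorophenyl gives an at least 4.8-fold higher number from compound 2 to compound 4 (0.68 log units; beyond the scatter). For compound 4, > 25000 nM is a limit of the assay, not a number. With this result, most of the series sits at that limit: the limit of > 25000 nM in this assay, at which 3 of the 4 values shown sit.

The compounds shown leave open whether the added methoxy groups or the missing fluorine accounts for this step. Neither plain phenyl nor a single 4-methoxyphenyl appears at this position to separate the two.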